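Guinea-pig trachea series: pyridin-3-yl for phenyl on compound 1

The compounds below may be only part of what the source reports. "The series", "measured", "known", "first", "only" and "open" are said of these compounds alone.

Measured so far in a functional assay on the whole organism (trachea) for inhibition, with Cavia porcellus as the target; on this read-out lower numbers stand for an effect already at smaller amounts and higher numbers for an effect only at larger amounts of compound:
compound 1, `O=C(O)CC/C=C\C[C@@H]1CN(Cc2ccccc2)C[C@@H]1c1ccccc1O`: 0.17 mg/kg
compound 2, `O=C(O)CCC/C=C\C[C@@H]1CN(S(=O)(=O)c2cccc3ccccc23)C[C@@H]1c1ccccc1O`: 0.08 mg/kg
compound 3, `O=C(O)CC/C=C\C[C@@H]1CN(S(=O)(=O)c2cccc3cnccc23)C[C@@H]1c1ccccc1O`: 0.011 mg/kg

Compound 1 stands highest of the three numbers in this assay. Compound 2 sits at a lower number than compound 1, beyond the scatter, and compound 3 sits lowest, well beyond the scatter from compound 1. Compounds 2 and 3 each differ from compound 1 in more than one place, so no single change can be read from them; these comparisons show only the two values of each pair.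

Compound 4, `O=C(O)CC/C=C\C[C@@H]1CN(Cc2cccnc2)C[C@@H]1c1ccccc1O`, has not been measured in this assay. It differs from compound 1 in one place: pyridin-3-yl in place of phenyl on a saturated chain carbon bound to an amine nitrogen in a ring. Going by the values given here, no measured pair in this set isolates that change, so its size is open. The expectation is a small step, if any, with the number for compound 4 estimated near that of compound 1, and the step of a 1.1-fold lower number from compound 1 to compound 4 (0.05 log units; within the scatter) is expected to lie within the scatter. Compound 4 is estimated at 0.15 mg/kg, with a range from 0.05 mg/kg to 0.45 mg/kg.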

Compound 4, dose for 50% inhibition: 1 mg/kg
Estimate against measurement, compound 4: 6.7-fold (0.82 log units) below, and the stated range ends below it.
By their numbers in this assay, from the lowest: compound 3; then compound 2; then compound 1; then compound 4.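

In this assay, going by these compounds alone, pyridin-3-yl in place of phenyl on a saturated chain carbon bound to an amine nitrogen in a ring gives a 5.9-fold higher number from compound 1 to compound 4 (0.77 log units; beyond the scatter) and so provides the first single change that can be read. This position is not indifferent to the swap: bringing in a ring nitrogen and a hydrogen-bond acceptor, with no net charge on either group, moves the number beyond the scatter, and benzyl holds the lower number on the core of compound 1. No measurement at hand accounts for the step.

Going by these compounds, whether pyridin-2-yl, pyridin-4-yl or a pyrimidinyl group on the same carbon would give a similar step remains open. On these data alone, compound 2 and compound 3 differ from compound 1 in more than one place, so whether the change carries over to their sulfonyl-bearing structures also remains open.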